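Pyrazole to Benzothiophene: Expected Clearance of Compound 4

The compounds below may be only part of what the source reports. "The series", "measured", "known", "first", "only" and "open" are said of these compounds alone.

Compound 3 `CC(C)n1cc(-c2cc(C(O)(C(F)(F)F)C(F)(F)F)cnc2N2CCN(S(=O)(=O)c3ccc(N)nc3)CC2)cn1` gives the highest of the three numbers in an ADME assay (liver) for metabolic stability, with Liver microsome (Homo sapiens) as the target, using microsomes and NADPH, with a stated time of 30 min, tested at 1 uM (on this read-out higher numbers stand for fast clearance and lower numbers for slow clearance), at 38 mL.min-1.g-1. Compound 2 `Cn1cc(-c2cc(C(O)(C(F)(F)F)C(F)(F)F)cnc2N2CCN(S(=O)(=O)c3ccc(N)nc3)CC2)cn1` gives 19 mL.min-1.g-1, a gap described by a 2.0-fold higher number from compound 2 to compound 3 (0.30 log units; within the scatter), and compound 1 `COCC#Cc1cc(C(O)(C(F)(F)F)C(F)(F)F)cnc1N1CCN(S(=O)(=O)c2ccc(N)nc2)CC1` gives 15 mL.min-1.g-1, with a 2.5-fold higher number from compound 1 to compound 3 (0.40 log units; beyond the scatter). Compound 4 `Nc1ccc(S(=O)(=O)N2CCN(c3ncc(C(O)(C(F)(F)F)C(F)(F)F)cc3-c3cc4ccccc4s3)CC2)cn1` carries the change (1-benzothiophen-2-yl in place of 1-isopropyl-1H-pyrazol-4-yl on an aromatic carbon). Within the data shown here, the steps that bear on it are the two earlier replacements on the same aromatic carbon, a 1.3-fold higher number from compound 1 to compound 2 (0.10 log units; within the scatter) and a 2.5-fold higher number from compound 1 to compound 3 (0.40 log units; beyond the scatter), the second modest and both pointing toward faster clearance. On that basis compound 4 is expected to show a further modest rise, a 1.6-fold higher number from compound 3 to compound 4 (0.20 log units; within the scatter). Compound 4 is therefore estimated at 60 mL.min-1.g-1, with a range from 25 mL.min-1.g-1 to 150 mL.min-1.g-1.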

Compound 4, intrinsic clearance in microsomes: < 14 mL.min-1.g-1
Compound 4: only a limit was reported; the forecaster's own chance of this, stated with the estimate: 5%; at least 4.2-fold (0.63 log units) between middle value and limit.
By their numbers in this assay, from the lowest: compounds 1, 2 and 3 (each within the scatter of the next, the first and the last beyond it). At a limit, below all of these: compound 4.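

Compound 4 is reported only as a limit in this assay: the limit of < 14 mL.min-1.g-1 in this assay, at which 1 of the 4 values shown sits.

This aromatic carbon therefore does not only move the number upward, as 1-benzothiophen-2-yl in place of 1-isopropyl-1H-pyrazol-4-yl gives an at least 2.7-fold lower number from compound 3 to compound 4 (0.43 log units; beyond the scatter). Against the other two compounds only floors within the scatter can be stated, an at least 1.3-fold lower number from compound 2 to compound 4 (0.13 log units; that floor lies within the scatter) and an at least 1.0-fold lower number from compound 1 to compound 4 (0.02 log units; that floor lies within the scatter).

From the compounds shown here alone, how far compound 4 really lies from compound 1 and compound 2 stays open. Also open, going by these compounds, is whether the fused benzene ring is needed, or whether a plain thiophen-2-yl or phenyl at this carbon would give the same result.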